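The source may hold more compounds than are shown below. What is called first, only, known or untested is meant among the compounds shown, and "the series" means these compounds.

Measured compounds:
compound 1, `CCCCn1cnc2c(Nc3cccc(Cl)c3)nc(NCOCc3ccc(/C=C/C(=O)Nc4ccccc4N)cc3)nc21`: 25.7%
compound 2, `Cc1ccc(Nc2nc(Cl)nc3c2ncn3Cc2ccc(C(=O)Nc3ccccc3N)cc2)cc1`: 67.3%
compound 3, `CC1CCN(c2nc(Cl)nc3c2ncn3Cc2ccc(/C=C/C(=O)Nc3ccccc3N)cc2)CC1`: 8.24%

In a functional assay on NCI-H460 cells (Homo sapiens) for antiproliferative activity, read by CCK-8 assay, with a stated time of 72 h, tested at 2 uM (a lower number here means a weaker effect, a higher number a stronger effect of the compound at the concentration tested), compound 1 gives 25.7%, the second highest of the three numbers. Compound 3 comes nearest, with a lower number beyond the usual scatter, and compound 2 stands furthest off, with a higher number, also beyond the scatter. Going by the values given here, no pair among the three differs in a single place, and none of these gaps can be read as the step of one change.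

Compound 4, `CC(C)n1cnc2c(Nc3cccc(Cl)c3)nc(NCOCc3ccc(/C=C/C(=O)Nc4ccccc4N)cc3)nc21`, is unmeasured. It differs from compound 1 by isopropyl in place of butyl on an aromatic nitrogen; the rest of the molecule is unchanged. Compounds 2 and 3 differ from compound 1 in several places at once and give no guide to what isopropyl in place of butyl on this aromatic nitrogen does. With nothing pointing in either direction, the step from compound 1 to compound 4 in this assay is expected to be small, if any, and within the scatter, that is a number 1.7 percentage points lower from compound 1 to compound 4 (within the scatter). Compound 4 is accordingly estimated at 24%, with a range from 10% to 40%.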

Compound 4, a percentage reported as inhibition, at one concentration (the size of the read-out at that concentration, not a potency): 53%
Compound 4: the middle estimate sits 29 percentage points below what was measured, and the stated range ends below it.
By their numbers in this assay, from the lowest: compound 3; then compound 1; then compound 4; then compound 2.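

In this assay, going by these compounds alone, the group on this aromatic nitrogen of the five-membered ring proves to matter: isopropyl in place of butyl gives a number 27.3 percentage points higher from compound 1 to compound 4 (beyond the scatter) and is the first change that can be read on its own. Butyl and isopropyl are both plain carbon groups with no ring, hydrogen-bond donor, hydrogen-bond acceptor or net charge, so an exchange between two such groups is enough to move the read-out beyond the scatter. No measurement at hand accounts for this step.

On these data alone, whether the shorter chain or the branched shape carries the step stays open, and a propyl, an ethyl or a cyclopentyl group on this nitrogen would help to separate the two. As far as these compounds go, whether the step holds on the cores of compound 2 and compound 3 also stays open.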